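Working notes: amine analogues in the cell-growth series

This account rests on a few compounds, and the source may have more. Where it says the series, first, only, none or still open, it means among the compounds named here.

Measured so far:
- compound 1, `CCOc1ccc(-c2nn3cc(-c4cccc(N)c4)nc3s2)cc1`: 155000 nM
- compound 2, `C=C(Br)C(=O)Nc1cccc(-c2cn3nc(-c4ccc(OCC)cc4)sc3n2)c1`: 790 nM
- compound 3, `Nc1cccc(-c2cn3c(-c4ccccc4)csc3n2)c1`: 85000 nM

In a functional assay on L1210 cells (Mus musculus) for inhibition, read by cell counting, with a stated time of 2 days (on this read-out higher numbers stand for weaker inhibition and lower numbers for stronger inhibition), compound 1 gives the highest of the three numbers. Compound 3 stands nearest, and the two values lie within the usual scatter of each other, so no order between compound 1 and compound 3 is claimed; compound 3 also carries a different core from compound 1. Within the data shown here, compound 2 stands furthest from compound 1, and the one step available in the set, a 200-fold lower number from compound 1 to compound 2 (2.29 log units; beyond the scatter), is large.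

Compound 4, `Nc1cccc(-c2cn3nc(-c4ccc(F)cc4)sc3n2)c1`, is not yet measured. It differs from compound 1 by fluoro in place of ethoxy on an aromatic carbon. Among the measured compounds shown here, no measured step bears on this change: the only step in the set concerns the substituent on the aromatic nitrogen, and nothing in the data varies the group on the aromatic carbon of the six-membered aromatic ring of carbon only. Compound 4 keeps the free aromatic amine of compound 1 and compound 3, both of which give high numbers in this assay. The expected step is therefore none beyond the scatter, a 1.2-fold lower number from compound 1 to compound 4 (0.08 log units; within the scatter). Compound 4 is expected to give about 130000 nM in this assay, with a range from 40000 nM to 400000 nM. In this assay compound 1 gives 155000 nM and compound 3 gives 85000 nM. Given these high numbers for the amines, there is a fair chance that only a limit of the assay is reported for compound 4.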

Compound 4, half-maximal inhibitory concentration: >= 250000 nM
Compound 4: a limit, no number; the forecaster's own chance of this, stated with the estimate: 25%; middle value at least 1.9-fold (0.28 log units) from the limit.
By their numbers in this assay, from the lowest: compound 2; then compounds 3 and 1 (each within the scatter of the next). At a limit, above all of these: compound 4.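

Fluoro in place of ethoxy, on an aromatic carbon of a six-membered aromatic ring of carbon only and para to a large group, is the first change at this position, and in this assay compound 4 gives >= 250000 nM, which is a limit of the assay and not a number. The step reads an at least 1.6-fold higher number from compound 1 to compound 4 (0.20 log units; that floor lies within the scatter), so this change brings no lower number to the free aromatic amine, and the true size of the step cannot be read. Among the compounds shown, only compound 4 stands at a limit: the limit of >= 250000 nM in this assay, at which 1 of the 4 values shown sits.

The compounds shown leave open whether (1-bromoethenyl)carbonyl on the nitrogen of compound 4 would bring a step like a 200-fold lower number from compound 1 to compound 2 (2.29 log units; beyond the scatter), which so far is seen only with ethoxy in place. They also leave open how chloro, methoxy or a longer alkoxy chain at this position would read in this assay, on the free amine or on the acylated nitrogen of compound 2.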